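The compounds below may be only part of what the source reports. "The series", "measured", "known", "first", "only" and "open" are said of these compounds alone.

For the measured compounds named here, compound 1 `COc1ncnc2c1c(-c1ccoc1)cn2[C@@H]1O[C@H](CO)[C@@H](O)[C@H]1O` has been tested in a functional assay on HL-60 cells (Homo sapiens) for antiproliferative activity, read by XTT assay, with a stated time of 72 h (a lower number here means a stronger inhibitor, a higher number a weaker inhibitor), and gives 150 nM, the only actual number in this set. Going by the values given here, the one other value shown belongs to compound 2 `COc1nc(N)nc2c1c(-c1ccoc1)cn2[C@@H]1O[C@H](CO)[C@@H](O)[C@H]1O`, which in this assay gives > 20000 nM, a limit of the assay and not a number. The step of an at least 130-fold higher number from compound 1 to compound 2 (2.12 log units; beyond the scatter) is accordingly anchored at the limit of > 20000 nM in this assay, at which 1 of the 2 values shown sits, so only its lower bound is known.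

Compound 3 `C#Cc1cn([C@@H]2O[C@H](CO)[C@@H](O)[C@H]2O)c2ncnc(OC)c12` has not yet been measured in this assay. It departs from compound 1 in one place: ethynyl in place of furan-3-yl on an aromatic carbon. The single measured step in this set concerns a different group at a different place, an amino in place of hydrogen, so no measured step bears on the change from compound 1 to compound 3, and the numbers shown give no direction for it. The step of a 1.3-fold higher number from compound 1 to compound 3 (0.12 log units; within the scatter) is therefore expected to stay within the usual scatter. Compound 3 is estimated at 200 nM, in a range from 40 nM to 1500 nM, with the wide range reflecting the absence of any bearing step.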

Compound 3, half-maximal inhibitory concentration: 190 nM
Beside the measured number, compound 3's estimate is 1.1-fold (0.02 log units) above it; low and high end bracket the measured number.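

In this assay, ethynyl in place of furan-3-yl on this aromatic carbon gives a 1.3-fold higher number from compound 1 to compound 3 (0.10 log units; within the scatter), so the two compounds cannot be told apart. Compound 3 thus shows what compound 1 and compound 2 could not: at this carbon of the five-membered aromatic ring, a group of 2 heavy atoms with no ring and a triple bond reads the same as a group of 5 heavy atoms with one five-membered aromatic ring, and the furan ring and its oxygen are not needed for a number of this size. Nothing shown gives a reason for this match, and the one limit on record concerns the amino step at a different place.

What an amine, a phenyl ring or a longer alkyl chain would give on this same carbon remains open, so the two groups shown mark no boundary for the position. Also open, on these data alone, is whether amino in place of hydrogen on the aromatic carbon would weigh on the ethynyl compound 3 as it did on the furan-3-yl compound 1.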